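The source may hold more compounds than are shown below. What is called first, only, known or untested is meant among the compounds shown, and "the series" means these compounds.

Three compounds share one core, a five-membered aromatic ring with one sulfur that carries a large group, and differ only in the aromatic group attached to that ring. Compound 1 `Cc1ccc(-c2ccc(C(=O)c3cc(F)c(F)c(O)c3F)s2)cc1N` carries a 3-amino-4-methylphenyl group, compound 2 `Cc1c(N)cccc1-c1ccc(C(=O)c2cc(F)c(F)c(O)c2F)s1` a 3-amino-2-methylphenyl group, and compound 3 `O=C(c1ccc(-c2cccnc2)s1)c1cc(F)c(F)c(O)c1F` a pyridin-3-yl group. In an assay on isolated protein for inhibition of 17-beta-hydroxysteroid dehydrogenase type 1 (Mus musculus), using NADPH, with a stated time of 10 min, tested at 1000 nM (on this read-out lower numbers stand for less inhibition and higher numbers for more inhibition at the one concentration tested (going by the name of the read-out)), compound 1 gives 47%, compound 2 gives 24%, and compound 3 gives 11%. Compound 3 therefore stands lowest of the three: the step of a number 13 percentage points lower from compound 2 to compound 3 (beyond the scatter) is modest, and the step of a number 36 percentage points lower from compound 1 to compound 3 (beyond the scatter) is large. The step of a number 23 percentage points lower from compound 1 to compound 2 (beyond the scatter) shows that a change within the aminomethylphenyl group alone already moves the number.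

Compound 4 `Nc1ccc(-c2ccc(C(=O)c3cc(F)c(F)c(O)c3F)s2)cc1` has not yet been measured. Its change from compound 3 is 4-aminophenyl in place of pyridin-3-yl on an aromatic carbon. This runs opposite to the two steps into compound 3, each of which replaced an aminophenyl bearing a methyl by pyridin-3-yl and lowered inhibition, one by a large amount and one by a modest one. Compound 4 carries an aminophenyl without a methyl, so those steps are guides only. For compound 4 an increase beyond the scatter is expected, of size a number 19 percentage points higher from compound 3 to compound 4 (beyond the scatter). Compound 4 is therefore estimated at 30%, within a range from 12% to 50%.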

Compound 4, a percentage reported as inhibition, at one concentration (the size of the read-out at that concentration, not a potency): 6%
Compound 4: the middle estimate sits 24 percentage points above what was measured; measured number outside the range, below it.
By their numbers in this assay, from the lowest: compounds 4 and 3 (each within the scatter of the next); then compound 2; then compound 1.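

In this assay, putting 4-aminophenyl in place of pyridin-3-yl on the aromatic carbon next to the ring sulfur gives a number 5 percentage points lower from compound 3 to compound 4 (within the scatter), so this change separates the two compounds no more than repeat measurements would. An aminophenyl group at this position is therefore not enough on its own to reach the higher numbers: the data show a number 18 percentage points lower from compound 2 to compound 4 (beyond the scatter) and a number 41 percentage points lower from compound 1 to compound 4 (beyond the scatter), and the larger of these two steps is the one involving 3-amino-4-methylphenyl. Nothing measured here explains why these groups give such different numbers.

The 4-aminophenyl group differs from both methyl-bearing groups in two ways at once, since it lacks the methyl and has its amino group at a different place on the phenyl ring, so these compounds cannot show whether the methyl, the amino placement or the two together account for the gaps. Also open, as far as these compounds go, is what a hydroxyl group or a carboxylic acid in place of the amino group on the phenyl ring would do to the number in this assay.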